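Moving a Methyl Group on a Pyridine-Thiosemicarbazone Series

The source may report more compounds than this note shows. Statements on the series, on what has been measured and on what is new or still open speak of the compounds shown alone.

Of the compounds shown here, three have been measured so far in a functional assay on HeLa cells (Homo sapiens) for cytotoxicity, read by MTT assay, with a stated time of 72 h; a higher number here means a weaker inhibitor, a lower number a stronger inhibitor. Compound 1, `Cc1cccc(/C(N)=N/NC(=S)N2CCN(c3ccccn3)CC2)n1`, gives 900 nM and is the lowest of the three numbers. Compound 2, `N/C(=N\NC(=S)N1CCCCCC1)c1ccccn1`, gives 6000 nM, and compound 3, `N/C(=N\NC(=S)N1CCOCC1)c1ccccn1`, gives 7300 nM. Both of these stand clearly beyond the scatter from compound 1, which therefore shows the strongest inhibition in this assay among the compounds measured. Among the measured compounds shown here, compound 2 and compound 3 differ from compound 1 in more than one place, so no single step between them can be read off.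

Compound 4, `Cc1ccnc(/C(N)=N/NC(=S)N2CCN(c3ccccn3)CC2)c1`, has not yet been measured. It differs from compound 1 in one place: 4-methylpyridin-2-yl in place of 6-methylpyridin-2-yl on a carbon with a double bond to nitrogen. The two compounds contain the same atoms, joined differently. For the measured compounds named here, no measured pair shows what moving the methyl group on this ring does in this assay, so the direction of the step is open. Going by the values given here, with no comparable step on record, the expectation for the move from compound 1 to compound 4 is a modest shift, a 1.7-fold higher number from compound 1 to compound 4 (0.22 log units; within the scatter), leaning toward a somewhat higher number but possibly staying within the scatter. Compound 4 is therefore estimated at 1500 nM, within a range of 400 nM to 6000 nM.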

Compound 4, half-maximal inhibitory concentration: 10500 nM
Compound 4: middle estimate off by 7.0-fold (0.85 log units), on the low side; the whole stated range lies below it.
By their numbers in this assay, from the lowest: compound 1; then compounds 2, 3 and 4 (each within the scatter of the next).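

Moving the methyl group on this ring is the first single change on record in this series, and in this assay it brings a 12-fold higher number from compound 1 to compound 4 (1.07 log units; beyond the scatter). The 6-methylpyridin-2-yl and 4-methylpyridin-2-yl groups match in heavy atoms, hydrogen-bond donors and hydrogen-bond acceptors, so only the placement of the methyl group separates compound 1 from compound 4, and that placement alone makes a large difference to the number in this assay. Nothing on hand gives a reason for the size of this step.

The compounds shown leave open whether the 6-methyl placement raises activity or the 4-methyl placement lowers it, and a plain pyridin-2-yl group with no methyl on the core of compound 1 would serve as the missing reference, while an ethyl or methoxy group in place of the methyl would test whether the methyl itself matters. They also leave open whether a step of this size would hold if the group at the other end of the molecule were changed.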